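The source may hold more compounds than are shown below. What is called first, only, known or untested is meant among the compounds shown, and "the series" means these compounds.

Measured compounds in a functional assay on MCF7 cells (Homo sapiens) for inhibition, read by MTT assay, with a stated time of 72 h; on this read-out higher numbers stand for weaker inhibition of growth and lower numbers for stronger inhibition of growth:

compound 1, `COc1ccc(CNC(=O)/C(C#N)=C/c2ccc3ccccc3c2)cc1`: 33000 nM
compound 2, `COc1ccc(CNC(=O)/C(C#N)=C/c2cccc3ccccc23)cc1`: 16000 nM
compound 3, `N#C/C(=C\c1ccc2ccccc2c1)C(=O)NCc1ccc(Cl)c(Cl)c1`: 29000 nM

Compound 1 and compound 2 are built from the same atoms joined differently; the difference between the two cores is not broken down here. What the two values show is that compound 2 gives a lower number in this assay than compound 1, a gap beyond the scatter, while compound 2 and compound 3 sit within the scatter of each other.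

One change has been measured once. From compound 1 to compound 3 the change is 3,4-dichlorophenyl in place of 4-methoxyphenyl on a saturated chain carbon bound to an amide-type nitrogen, and in this assay it produced a 1.1-fold lower number from compound 1 to compound 3 (0.06 log units; within the scatter). The step is within the scatter, so on the core of compound 1 the exchange of 4-methoxyphenyl for 3,4-dichlorophenyl left the growth inhibition of MCF7 cells essentially unchanged.

Compound 4, `N#C/C(=C\c1cccc2ccccc12)C(=O)NCc1ccc(Cl)c(Cl)c1`, has not been measured. It differs from compound 2 by 3,4-dichlorophenyl in place of 4-methoxyphenyl on a saturated chain carbon bound to an amide-type nitrogen. The place is the same word for word as for the pair compound 1 and compound 3, so this is the same change, now made on the core of compound 2. For the measured compounds named here, with only that one precedent, the step from compound 2 to compound 4 in this assay is expected to be about as small, a 1.1-fold lower number from compound 2 to compound 4 (0.06 log units; within the scatter), because the same change gave a 1.1-fold lower number from compound 1 to compound 3 (0.06 log units; within the scatter). From the compounds shown here alone, on that basis compound 4 is estimated at 14000 nM, with a range of 6000 nM to 32000 nM; whether the core of compound 2 responds to this change like the core of compound 1 is untested.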

Compound 4, concentration for 50% growth inhibition: 8000 nM
Compound 4: middle estimate off by 1.8-fold (0.24 log units), on the high side; measured number inside the range.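

In this assay the exchange of 4-methoxyphenyl for 3,4-dichlorophenyl on a saturated chain carbon bound to an amide-type nitrogen, now made on the second core, gave a 2.0-fold lower number from compound 2 to compound 4 (0.30 log units; within the scatter) as its reading. Set beside the earlier step, the two readings cannot be told apart, so the change carries over from one core to the other as far as this read-out can show: the same change on two cores in this assay, a 1.1-fold lower number (0.06 log units; within the scatter) from compound 1 to compound 3 and a 2.0-fold lower number (0.30 log units; within the scatter) from compound 2 to compound 4, 1.8-fold (0.24 log units) apart, within the scatter of two such steps. This does not show that the exchange improves growth inhibition on either core, since each step lies within the scatter, and two pairs with one reading per compound say nothing about how the change would behave on any further core.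

The compounds shown leave open how a phenyl ring carrying an amine or a carboxylic acid would behave in this same place, and whether a longer chain in place of the single saturated chain carbon would alter the reading in this assay. They also leave open whether the gap between compound 1 and compound 2, the only gap here beyond the scatter, would persist with other groups on the amide-type nitrogen.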